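Trifluoromethyl to chloro: one swap awaiting its measurement

The compounds below may be only part of what the source reports. "The series", "measured", "known", "first", "only" and "open" are said of these compounds alone.

Compound 1 `CN1C/C(=C\c2ccncc2)C(=O)/C(=C/c2ccccc2F)C1` gives 4600 nM
Compound 2 `O=C1/C(=C/c2ccncc2)CN(S(=O)(=O)c2ccc(C(F)(F)F)cc2)C/C1=C\c1ccccc1F` gives 4030 nM

Both values come from a functional assay on HepG2 cells (Homo sapiens) for cytotoxicity, read by MTT assay, with a stated time of 24 h (a higher number here means a weaker inhibitor, a lower number a stronger inhibitor), and lie within the scatter of each other, so compound 2 stands level with compound 1 and the two cannot be ranked.

Compound 3 `O=C1/C(=C/c2ccncc2)CN(S(=O)(=O)c2ccc(Cl)cc2)C/C1=C\c1ccccc1F` differs from compound 2 in one place (chloro in place of trifluoromethyl on an aromatic carbon), with chloro in place of trifluoromethyl on an aromatic carbon, para to a large group. Within the data shown here, no measured pair in this small set shows what such a swap does, so there is no step to lean on. Among the measured compounds shown here, the only guide is that compound 2 at 4030 nM sits within the scatter of compound 1 at 4600 nM in this assay and that the swap touches a single place. No shift in either direction beyond the scatter is expected. The estimated change is a 1.0-fold higher number from compound 2 to compound 3 (0.02 log units; within the scatter) and it is expected to stay inside the scatter. For compound 3 the estimated value is 4200 nM with an expected lower end of 2100 nM and an expected upper end of 8400 nM on this evidence.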

Compound 3, half-maximal inhibitory concentration: 5300 nM
The estimate for compound 3 lay 1.3-fold (0.10 log units) below the measured number; the range from low to high includes it.
By their numbers in this assay, from the lowest: compounds 2, 1 and 3 (each within the scatter of the next).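

In this assay, chloro in place of trifluoromethyl on an aromatic carbon, para to a large group, gives a 1.3-fold higher number from compound 2 to compound 3 (0.12 log units; within the scatter) and so leaves the two groups unseparated at this place, even though the heavy-atom count of the group differs. With chloro on the ring, the comparison on the amine nitrogen in the ring also stays level: (4-chlorophenyl)sulfonyl in place of methyl gives a 1.2-fold higher number from compound 1 to compound 3 (0.06 log units; within the scatter) and does not separate the larger group from methyl, just as the trifluoromethyl compound could not be ranked against compound 1. No measurement is available that could explain why these readings stay level.

Whether a methoxy group, an amine or a carboxylic acid at this place on the aromatic ring would step beyond the scatter remains open, since the two groups shown here, trifluoromethyl and chloro, cannot be told apart. Also open is what an acetyl group or a longer chain on the amine nitrogen in the ring would give, as the methyl and sulfonyl compounds shown leave that nitrogen without a measurable trend.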